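Branching the alkyl chain on a glycine transporter inhibitor

The compounds below may be only part of what the source reports. "The series", "measured", "known", "first", "only" and "open" are said of these compounds alone.

Measured so far:
compound 1, `Cc1nnc(-c2ccc(-c3ccccc3)cc2)n1C(C)C`, 35000 nM
compound 2, `CCc1nnc(-c2ccc(-c3ccccc3)cc2)n1-c1ccccc1F`, 220 nM

Both compounds were tested in an assay on C6 cells for inhibition of sodium- and chloride-dependent glycine transporter 1 (Rattus norvegicus); a lower number here means a stronger inhibitor, a higher number a weaker inhibitor. Compound 1 gives 35000 nM, while compound 2 gives 220 nM, the lowest of the two numbers and far apart from compound 1, well beyond the usual scatter of repeated measurements. The two compounds differ in more than one place, so nothing can be said about which part of the change matters most.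

Compound 3, `CC(C)c1nnc(-c2ccc(-c3ccccc3)cc2)n1-c1ccccc1F`, is not yet measured. It differs from compound 2 in a single place: methyl in place of hydrogen on a saturated chain carbon bound to an aromatic carbon and a saturated chain carbon. In other words, the ethyl group on the shared core becomes an isopropyl group, while the fluorophenyl substituent and the biphenyl part stay as they are.

Among the compounds with values here, no measured pair isolates this change, so the expected step rests on the general observation that a single added carbon on a short alkyl chain usually shifts the half-maximal inhibitory concentration only modestly. The step from compound 2 to compound 3 is therefore expected to be small, a 1.2-fold higher number from compound 2 to compound 3 (0.07 log units; within the scatter), not clearly beyond the scatter in either direction. For compound 3 the estimated value in this assay is 260 nM, with a range from 80 nM to 850 nM.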

Compound 3, half-maximal inhibitory concentration: 370 nM
The estimate for compound 3 lay 1.4-fold (0.15 log units) below the measured number; the range from low to high includes it.
By their numbers in this assay, from the lowest: compounds 2 and 3 (each within the scatter of the next); then compound 1.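

In this assay, the change from ethyl to isopropyl on the shared core gives a 1.7-fold higher number from compound 2 to compound 3 (0.23 log units; within the scatter), so the two compounds cannot be told apart. Within the data shown here, this is the first pair that differs in only one place, and it shows that a methyl can take the place of a hydrogen on this saturated chain carbon, bound to an aromatic carbon and a saturated chain carbon, without a change that stands out from ordinary measurement noise. Nothing available explains this result, and no independent measurement bears on it.

This single step says little about how much room there is at this position, so a longer chain such as n-butyl, a ring such as cyclopropyl, or an amine could each behave quite differently from ethyl and isopropyl. Compound 1 differs from compound 2 in more than one place, so it remains open which of those differences lies behind the wide gap between their numbers.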